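The compounds below may be only part of what the source reports. "The series", "measured", "known", "first", "only" and "open" are said of these compounds alone.

Measured values in a functional assay on L1210 cells (Mus musculus) for antiproliferative activity; a lower number here means a stronger inhibitor, a higher number a weaker inhibitor:
compound 1 `O=c1[nH]c(=O)n([C@H]2C[C@H](O)[C@@H](COP(=O)(O)O)O2)cc1Br` — 34.6 ug/mL
compound 2 `O=c1[nH]c(=O)n([C@H]2C[C@@H]3O[PH](O)(O)OC[C@H]3O2)cc1F` — 0.06 ug/mL
compound 3 `COP1(=O)OC[C@H]2O[C@@H](n3cc(Br)c(=O)[nH]c3=O)C[C@@H]2O1` — a limit, > 100 ug/mL

Compound 2 gives the lowest of the two numbers recorded in this assay; the nearest number, that of compound 1, lies higher by far more than the usual scatter. Compound 3 sits at the assay limit, (the limit of > 100 ug/mL in this assay, at which 1 of the 3 values shown sits). Going by the values given here, neither compound 1 nor compound 3 differs from compound 2 in one place only, so no single step between measured compounds is available.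

Compound 4 `O=c1[nH]c(=O)n([C@H]2C[C@@H]3O[PH](O)(O)OC[C@H]3O2)cc1I` is not yet measured. Its change from compound 2: iodo in place of fluoro on an aromatic carbon. Among the compounds with values here, with no measured step to lean on, the size is uncertain; a step in this assay toward a higher number, beyond the scatter, is expected. Compound 4 is estimated at 3 ug/mL, range 0.1 ug/mL to 60 ug/mL, meaning an expected step of a 50-fold higher number from compound 2 to compound 4 (1.70 log units; beyond the scatter).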

Compound 4, concentration for 50% inhibition: >= 500 ug/mL
Compound 4 was reported as a limit; the forecaster's own chance of this, stated with the estimate: 15%; middle value at least 160-fold (2.22 log units) away from the limit.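

In this assay, the aromatic carbon carrying the halogen proves highly sensitive within the core of compound 2: iodo in place of fluoro gives an at least 8300-fold higher number from compound 2 to compound 4 (3.92 log units; beyond the scatter). Compound 1 and compound 3 differ from compound 2 in more than one place and could not show this. The value of compound 4 is a limit, not a number, so the true size of the step remains unknown: the limit of >= 500 ug/mL in this assay, at which 1 of the 4 values shown sits.

Open, from the compounds shown here alone, is where chloro, methyl or an amine on this carbon would fall on the core of compound 2. A single pair also cannot show whether the response follows any trend across groups.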